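Chloro to hydroxy on compound 3

The source may hold more compounds than are shown below. What is called first, only, known or untested is meant among the compounds shown, and "the series" means these compounds.

In a functional assay on A549 cells (Homo sapiens) for cytotoxicity, read by MTT assay, with a stated time of 72 h (on this read-out lower numbers stand for stronger inhibition and higher numbers for weaker inhibition), compound 1 (`COc1ccc(/C=C2\CCC/C(=C\c3ccc(Cl)c(Cl)c3)C2=O)cc1OC`) gives 6900 nM and compound 2 (`COc1ccc(/C=C2\CCC/C(=C\c3cc(Cl)cc(Cl)c3)C2=O)cc1OC`) gives 5500 nM in the same read-out, with a 1.3-fold lower number from compound 1 to compound 2 (0.10 log units; within the scatter) separating them. Compound 3 (`COc1ccc(/C=C2\CCC/C(=C\c3ccc(O)c(Cl)c3)C2=O)cc1OC`) is reported at > 20000 nM as a limit and not as a number.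

Compound 4 (`COc1ccc(/C=C2\CCC/C(=C\c3ccc(O)c(O)c3)C2=O)cc1OC`) differs from compound 3 by hydroxy in place of chloro on an aromatic carbon in a single exchange: hydroxy in place of chloro on an aromatic carbon, ortho to a hydroxy group, taking 3-chloro-4-hydroxyphenyl to 3,4-dihydroxyphenyl. The same exchange gave an at least 2.8-fold higher number from compound 1 to compound 3 (0.46 log units; beyond the scatter) on its one earlier occurrence, and the wider change gave an at least 3.6-fold higher number from compound 2 to compound 3 (0.56 log units; beyond the scatter) as well. Both steps run toward higher numbers, but each ends on a limit and fixes direction rather than size.

A further modest move toward higher numbers is therefore expected in this assay for this exchange, and another limit may be reported instead of a number. The estimated change is a step that the limit leaves unreadable from compound 3 to compound 4 on this reasoning. Compound 4 is expected near 30000 nM with 10000 nM to 80000 nM as the estimated range.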

Compound 4, half-maximal inhibitory concentration: > 20000 nM
Compound 4: a limit, no number; the forecaster's own chance of this, stated with the estimate: 60%; the middle value does not contradict the limit.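

Exchanging the remaining chloro of compound 3 for hydroxy gives compound 4, which is also reported only as a limit in this assay, and the step between them cannot be read. The 3,4-dihydroxyphenyl compound shows that this change brings no return toward the dichlorophenyl compounds, with an at least 3.6-fold higher number from compound 2 to compound 4 (0.56 log units; beyond the scatter) and an at least 2.8-fold higher number from compound 1 to compound 4 (0.46 log units; beyond the scatter). Compound 3 and compound 4 thus share the same ceiling on this read-out: the limit of > 20000 nM in this assay, at which 2 of the 4 values shown sit.

From the compounds shown here alone, how far either compound lies beyond that limit remains open, so the exchange could have had no effect or a substantial one. Also open, going by these compounds, is whether an amine or a carboxylic acid at this position, in place of the hydroxy, would bring the number back within the range of compound 1 and compound 2.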